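The compounds below may be only part of what the source reports. "The series", "measured", "known", "first", "only" and "open" are said of these compounds alone.

Measured in an ADME assay on HepG2 cells (Homo sapiens) for cytotoxicity, in the presence of a further agent that is not named here; a higher number here means a weaker inhibitor, a lower number a stronger inhibitor:
- compound 1 `Cn1c(Cc2ccccc2C(F)(F)F)nc(C(=O)Nc2ccccc2)c(O)c1=O`: > 100000 nM
- compound 2 `Cc1nc(C(=O)NCc2ccccc2)c(O)c(=O)n1C`: > 100000 nM

Neither entry is an exact number. In this assay compound 1 gives > 100000 nM, which is a limit of the assay and not a measured number. Compound 2 gives > 100000 nM, which is also a limit. Together, compound 1 and compound 2 show (the limit of > 100000 nM in this assay, at which 2 of the 2 values shown sit).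

Compound 3 `Cn1c(Cc2ccccc2C(F)(F)F)nc(C(=O)NCc2ccccc2F)c(O)c1=O` has not yet been measured. It has 2-fluorobenzyl in place of phenyl on an amide-type nitrogen. Within the data shown here, no pair of measured compounds differs in just one place, so the size of this step cannot be read directly from the data. With compound 1 and compound 2 showing (the limit of > 100000 nM in this assay, at which 2 of the 2 values shown sit), no step beyond the scatter is expected in this assay, in either direction. The expected outcome is a number no higher from compound 1 to compound 3 (the limit leaves the size open). For compound 3 the estimated value is 100000 nM, with an expected range of 50000 nM to 200000 nM.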

Compound 3, half-maximal inhibitory concentration: > 100000 nM
Compound 3 ended at the assay's limit; the forecaster's own chance of this, stated with the estimate: 85%; the middle value lies on the limit itself.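

Compound 1 and compound 3 both stand at a limit of this assay rather than at a measured number, so no step can be read between them: the limit of > 100000 nM in this assay, at which 3 of the 3 values shown sit.

The compounds shown leave open what exact value any of them has, and whether 2-fluorobenzyl in place of phenyl changes it at all.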